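Benzyl substituent swap and cytotoxicity in the series

The source may report more compounds than this note shows. Statements on the series, on what has been measured and on what is new or still open speak of the compounds shown alone.

Measured so far:
compound 1, `CCOC(=O)c1cnc(N2CCN(Cc3cccc(Br)c3)CC2)nc1Oc1c(C)cc(-c2ccc(C#N)cc2)cc1C`: in an ADME assay on MT4 cells (Homo sapiens) for cytotoxicity, read by MTT assay, with a stated time of 4 days (on this read-out higher numbers stand for lower toxicity in this test and lower numbers for higher toxicity in this test), compound 1 is reported only as a limit, > 125000 nM
compound 2, `CCOC(=O)c1cnc(N2CCN(Cc3cccc(C(N)=O)c3)CC2)nc1Oc1c(C)cc(-c2ccc(C#N)cc2)cc1C`: in this assay compound 2 gives 14800 nM

Among the compounds with values here, compound 2 holds the only number in this assay so far; the other value is a limit (the limit of > 125000 nM in this assay, at which 1 of the 2 values shown sits). Within the data shown here, the single step that bears on the benzyl substituent, an at least 8.4-fold lower number from compound 1 to compound 2 (0.92 log units; beyond the scatter), sets the scale of what this position can do, though it describes a different exchange.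

Compound 3, `CCOC(=O)c1cnc(N2CCN(Cc3ccc(S(N)(=O)=O)cc3)CC2)nc1Oc1c(C)cc(-c2ccc(C#N)cc2)cc1C`, is not yet measured. It differs from compound 2 by 4-sulfamoylphenyl in place of 3-carbamoylphenyl on a saturated chain carbon bound to an amine nitrogen in a ring. Among the measured compounds shown here, both groups carry one hydrogen-bond donor, and no measured step covers this exchange directly, so a step within the scatter or a modest one toward a higher number is expected in this assay, with a real chance that only a limit is reported. The estimate for compound 3 is 22000 nM, between 6000 nM and 125000 nM, corresponding to a 1.5-fold higher number from compound 2 to compound 3 (0.17 log units; within the scatter).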

Compound 3, half-maximal cytotoxic concentration: >= 7930 nM
Compound 3: only a limit was reported; the forecaster's own chance of this, stated with the estimate: 30%; the middle value is on the limit's open side.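

In this assay compound 3 is reported only as a limit, >= 7930 nM, so neither step to compound 3, from compound 2 or from compound 1, can be read. Going by these compounds, whether 4-sulfamoylphenyl and 3-carbamoylphenyl differ on this read-out stays open, as does how compound 3 stands against compound 1.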